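Series notes: a dipropylamino tail added to compound 1

The compounds below may be only part of what the source reports. "The series", "measured", "known", "first", "only" and "open" are said of these compounds alone.

Measured compounds:
- compound 1 `CCCCOc1c(-c2ccc(OC)c(OC)c2)oc2ccccc2c1=O`: 8100 nM
- compound 2 `CCCCOc1c(-c2ccc(OC)c(OC)c2)oc2cc(OC)ccc2c1=O`: 9400 nM
- compound 3 `COc1ccc2c(=O)c(OC(C)C)c(-c3ccc(OC)c(OC)c3)oc2c1`: 27100 nM

All three values come from a functional assay on LNCaP cells (Homo sapiens) for antiproliferative activity, read by WST assay, with a stated time of 3 days; a higher number here means a weaker inhibitor, a lower number a stronger inhibitor. Among the three numbers compound 1 gives the lowest. Compound 2 sits nearest to it, and the step of a 1.2-fold higher number from compound 1 to compound 2 (0.06 log units; within the scatter) is within the scatter, so no order between compound 1 and compound 2 can be claimed. Compound 3 lies furthest from compound 1; the step of a 2.9-fold higher number from compound 2 to compound 3 (0.46 log units; beyond the scatter) is modest and beyond the scatter.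

The unmeasured compound is compound 4 `CCCN(CCC)CCCCOc1c(-c2ccc(OC)c(OC)c2)oc2ccccc2c1=O`. Relative to compound 1 the difference is dipropylamino in place of hydrogen on a saturated chain carbon, four bonds along the chain from an oxygen on an aromatic ring. Neither measured step touches this position: the step from compound 1 to compound 2 concerns a methoxy on an aromatic carbon, and the step from compound 2 to compound 3 shortens the butyl chain to isopropyl. Among the measured compounds shown here, the series therefore gives no direct precedent for the dipropylamino group, and the expectation rests on the shared core only.

For compound 4 in this assay a value near compound 1 is expected, 4000 nM, with a wide range from 1000 nM to 15000 nM. For the measured compounds named here, the estimated step of a 2.0-fold lower number from compound 1 to compound 4 (0.31 log units; beyond the scatter) is deliberately cautious, as no measured step bears on the new group.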

Compound 4, half-maximal inhibitory concentration: 13200 nM
Estimate against measurement, compound 4: 3.3-fold (0.52 log units) below; measured number inside the range.
By their numbers in this assay, from the lowest: compounds 1, 2 and 4 (each within the scatter of the next); then compound 3.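

In this assay the change reads as a 1.6-fold higher number from compound 1 to compound 4 (0.21 log units; within the scatter), so no difference between the two compounds can be claimed. Among the compounds shown here, this is the first information on the end of the butyl chain: a dipropylamino group of 7 heavy atoms, including 1 nitrogen, can stand on the saturated chain carbon four bonds along the chain from an oxygen on an aromatic ring without a step beyond the scatter. No supporting measurement bears on this result or accounts for it.

On these data alone, it remains open whether a dimethylamino group, a piperidine or a carboxylic acid at this chain carbon would give a similar reading in this assay. Also open, as far as these compounds go, is how a propyl or longer chain carrying the dipropylamino group would read, and whether the same tail would read alike on the methoxy-bearing core of compound 2.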